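A few compounds are considered here, and "the series" means these few. Any claim that something is new, unique, unknown or untested is made for them only; others in the source may bear on it.

Compound 1 `O=c1cc(-c2ccccc2)oc2ccc(OCCCCCCN3CCCC(O)C3)cc12` in an assay on isolated protein (Cavia porcellus) with Sigma non-opioid intracellular receptor 1 (Homo sapiens) as the target, read by radioligand binding; on this read-out higher numbers stand for weaker inhibition and lower numbers for stronger inhibition: 86 nM
Compound 2 `O=c1cc(-c2ccccc2)oc2ccc(OCCCCCCN3CCNC(CCO)C3)cc12` in this assay: 63 nM

Among the measured compounds shown here, compound 2 gives the lower of the two numbers, but its only neighbour, compound 1, stands within the scatter of it, so the two are not separated. Compound 3 `O=c1cc(-c2ccccc2)oc2ccc(OCCCCCCN3CCNCC3c3ncccn3)cc12` is not yet measured; it differs from compound 2 by 2-(pyrimidin-2-yl)piperazin-1-yl in place of 3-(2-hydroxyethyl)piperazin-1-yl on a saturated chain carbon, six bonds along the chain from an oxygen on an aromatic ring. For the measured compounds named here, the single step that bears on this end of the chain is a 1.4-fold lower number from compound 1 to compound 2 (0.14 log units; within the scatter), which stayed within the scatter, so an exchange of the ring at this position has so far not moved the number. For compound 3 the expected step is therefore a 1.1-fold higher number from compound 2 to compound 3 (0.05 log units; within the scatter), none beyond the scatter. Compound 3 is estimated at 70 nM, with a range from 25 nM to 200 nM.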

Compound 3, half-maximal inhibitory concentration: 1630 nM
Beside the measured number, compound 3's estimate is 23-fold (1.37 log units) below it; the measured number lies above the stated range.
By their numbers in this assay, from the lowest: compounds 2 and 1 (each within the scatter of the next); then compound 3.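

In this assay this end of the chain proves sensitive: 2-(pyrimidin-2-yl)piperazin-1-yl in place of 3-(2-hydroxyethyl)piperazin-1-yl gives a 26-fold higher number from compound 2 to compound 3 (1.41 log units; beyond the scatter) and in place of 3-hydroxypiperidin-1-yl gives a 19-fold higher number from compound 1 to compound 3 (1.28 log units; beyond the scatter) as well. The earlier exchange at this place stayed within the scatter, so the ring exchange there does not hold for every group on a saturated chain carbon, six bonds along the chain from an oxygen on an aromatic ring. No data shown bear on the cause of this weakening.

The compounds shown leave open whether the weakening goes with the pyrimidin-2-yl ring or with the piperazine carrying a group at its 2-position. An unsubstituted piperazin-1-yl or a 2-phenylpiperazin-1-yl at this place would separate the two.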